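Swapping one ring at a cytotoxicity limit

A few compounds are considered here, and "the series" means these few. Any claim that something is new, unique, unknown or untested is made for them only; others in the source may bear on it.

Values measured in an ADME assay on RAW264.7 cells (Mus musculus) for cytotoxicity, read by MTT assay (on this read-out lower numbers stand for stronger inhibition and higher numbers for weaker inhibition), are as follows
Compound 1 `COc1ccc(/C=C/C=C/C(=O)c2ccco2)cc1` gives 76600 nM
Compound 2 `CN(C)c1ccc(/C=C/C=C/C(=O)c2ccccc2O)cc1` gives "not determined" (no result reported)
Compound 3 `CN(C)c1ccc(/C=C/C=C/C(=O)c2ccc(F)cc2)cc1` gives > 100000 nM

Compound 3 stands at the limit of > 100000 nM in this assay, at which 1 of the 3 values shown sits, and that entry is a limit of the assay, not a number. Among the compounds with values here, compound 4 `CN(C)c1ccc(/C=C/C=C/C(=O)c2ccco2)cc1` has furan-2-yl in place of 4-fluorophenyl on a carbonyl carbon as its one difference from compound 3. Within the data shown here, no two measured compounds differ in only one place, so no direct step is available as a guide. Compound 1 also carries furan-2-yl and gives 76600 nM in this assay so a modest move towards lower numbers is expected. The estimated change is an at least 1.4-fold lower number from compound 3 to compound 4 (0.15 log units; that floor lies within the scatter) and it is expected to stay small. The estimate for compound 4 is 70000 nM with an expected range from 30000 nM to 150000 nM in this read-out.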

Compound 4, half-maximal inhibitory concentration: > 100000 nM
Compound 4 ended at the assay's limit (the forecaster's own chance of this, stated with the estimate: 40%); middle value at least 1.4-fold (0.15 log units) from the limit.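

In this assay, compound 4 joins compound 3 at a limit, which is not a number: the limit of > 100000 nM in this assay, at which 2 of the 4 values shown sit. With both ends of the change from 4-fluorophenyl to furan-2-yl on a carbonyl carbon at that limit, the step cannot be read, so this position shows no measurable effect of the swap. With furan-2-yl kept, dimethylamino in place of methoxy on an aromatic carbon gives an at least 1.3-fold higher number from compound 1 to compound 4 (0.11 log units; that floor lies within the scatter).

Still open, going by these compounds, is whether a different group on that carbonyl carbon, such as a thiophene ring or a phenyl ring carrying a carboxylic acid, would give a readable number.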